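The source may hold more compounds than are shown below. What is called first, only, known or untested is meant among the compounds shown, and "the series" means these compounds.

Working notes on the series. For the measured compounds named here, the three measured members share one core and differ only in the aryl group attached to the carbonyl carbon of the amide. Compound 1 `COc1cc(C(=O)Nc2ccc(C(=O)/C=C/c3nc(C)c(C)nc3C)cc2)cc(OC)c1OC` carries a methoxy-bearing aryl group, and in a functional assay on MDA-MB-231 cells (Homo sapiens) for antiproliferative activity, read by CCK-8 assay, with a stated time of 72 h (on this read-out lower numbers stand for stronger inhibition and higher numbers for weaker inhibition), compound 1 gives 4740 nM. Compound 2 `Cc1nc(C)c(/C=C/C(=O)c2ccc(NC(=O)c3ccccc3F)cc2)nc1C` carries a 2-fluorophenyl group, and in this assay compound 2 gives 1980 nM. Compound 3 `COc1cccc(OC)c1C(=O)Nc1ccc(C(=O)/C=C/c2nc(C)c(C)nc2C)cc1` carries a 2,6-dimethoxyphenyl group, and in this assay compound 3 gives 3850 nM, the second highest of the three numbers; compound 1 is nearest and compound 2 furthest, both within the scatter. Going by the values given here, the single one-point step measured so far is a 1.9-fold higher number from compound 2 to compound 3 (0.29 log units; within the scatter), which stays within the scatter.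

Compound 4 `Cc1ccc(C(=O)Nc2ccc(C(=O)/C=C/c3nc(C)c(C)nc3C)cc2)cc1` is not yet measured. Against compound 3 the change is 4-methylphenyl in place of 2,6-dimethoxyphenyl on a carbonyl carbon. Among the compounds with values here, the only step that bears on it, the one from compound 2 to compound 3, stayed within the scatter, and compound 1 with its own aryl group also lies within the scatter of compound 3, so swapping the aryl group on this carbonyl has so far moved the number little. No step beyond the scatter is therefore expected in this assay. Compound 4 is expected to give 3500 nM, with a range of 1500 nM to 8000 nM. The expected step is a 1.1-fold lower number from compound 3 to compound 4 (0.04 log units; within the scatter).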

Compound 4, half-maximal inhibitory concentration: 1780 nM
The estimate for compound 4 lay 2.0-fold (0.29 log units) above the measured number; low and high end bracket the measured number.
By their numbers in this assay, from the lowest: compounds 4, 2, 3 and 1 (each within the scatter of the next, the first and the last beyond it).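

In this assay, the aryl group on a carbonyl carbon whose other neighbours are amide-type nitrogen now gives its first step beyond the scatter, a 2.2-fold lower number from compound 3 to compound 4 (0.34 log units; beyond the scatter), with 4-methylphenyl in place of 2,6-dimethoxyphenyl; the position is therefore not wholly indifferent to this swap, though the step is modest. The second new step, a 1.1-fold lower number from compound 2 to compound 4 (0.05 log units; within the scatter), with 4-methylphenyl in place of 2-fluorophenyl, stays within the scatter, so this pair cannot be told apart and the shift appears only against the 2,6-dimethoxyphenyl compound. No measurement at hand bears on the reason for the step seen with 4-methylphenyl.

The step from 2,6-dimethoxyphenyl to 4-methylphenyl changes the kind, number and placing of the substituents at once, so the compounds shown cannot say which of these matters. Also open, as far as these compounds go, is whether an amine or a carboxylic acid in place of the methyl of 4-methylphenyl, or a longer chain such as ethyl there, would move the number beyond the scatter of compound 4.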